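From nitro to methoxy on an aromatic carbon

This account rests on a few compounds, and the source may have more. Where it says the series, first, only, none or still open, it means among the compounds named here.

Compound 1 `O=C1C=CCC/C1=C\C=C\c1ccccc1`: 4200 nM
Compound 2 `O=C1C=CCC/C1=C\C(Br)=C\c1ccccc1`: > 10000 nM (a limit, not a number)
Compound 3 `O=C1C=CCC/C1=C\C=C\c1ccccc1[N+](=O)[O-]`: 4600 nM
Compound 4 `COc1ccccc1/C=C/C=C1\CCC=CC1=O`: not yet measured

In a functional assay on Bel-7402 cells (Homo sapiens) for cytotoxicity, read by MTT assay, with a stated time of 72 h (on this read-out lower numbers stand for stronger inhibition and higher numbers for weaker inhibition), compound 3 gives 4600 nM and lies within the scatter of compound 1 (4200 nM). The entry for compound 2 (> 10000 nM) is a limit.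

Compound 4 differs from compound 3 by methoxy in place of nitro on an aromatic carbon, ortho to a large group (methoxy in place of nitro on an aromatic carbon). The closest measured step is the one that put nitro in place of hydrogen on an aromatic carbon (a 1.1-fold higher number from compound 1 to compound 3 (0.04 log units; within the scatter)). The other step (an at least 2.3-fold higher number from compound 1 to compound 2 (0.37 log units; beyond the scatter)) put bromo in place of hydrogen on the chain, so it concerns a different place and bears less on this change.

Compound 3 at 4600 nM carries nitro with no step beyond the scatter from compound 1, so no step beyond the scatter is expected in this assay when methoxy enters. Methoxy itself has not been measured on this core, which keeps the range wide. An estimated 1.0-fold lower number from compound 3 to compound 4 (0.01 log units; within the scatter) is what this suggests. For compound 4 the estimated value is 4500 nM with an expected range of 2000 nM to 10000 nM on this read-out.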

Compound 4, half-maximal inhibitory concentration: 2600 nM
Beside the measured number, compound 4's estimate is 1.7-fold (0.24 log units) above it, within the range that was stated.
By their numbers in this assay, from the lowest: compounds 4, 1 and 3 (each within the scatter of the next). At a limit, above all of these: compound 2.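

In this assay the aromatic carbon ortho to a large group has now taken hydrogen, nitro and methoxy, and neither new step leaves the scatter: a 1.8-fold lower number from compound 3 to compound 4 (0.25 log units; within the scatter) and a 1.6-fold lower number from compound 1 to compound 4 (0.21 log units; within the scatter). The earlier compounds shown here showed only that nitro could replace hydrogen at this place without a step beyond the scatter; the new result adds that the same holds for methoxy, and for the exchange of nitro, with its 3 heavy atoms and 2 hydrogen-bond acceptors, for methoxy, with 2 heavy atoms and 1 hydrogen-bond acceptor. So across these three compounds this position shows no step beyond the scatter, and no measured property among the data shown accounts for that.

As far as these compounds go, whether an amine, a carboxylic acid or a longer chain such as ethoxy on this aromatic carbon would give a step beyond the scatter remains open. From the compounds shown here alone, it is also open whether methoxy would behave the same way on the other carbons of the aromatic ring, or with bromo on the chain of the shared core.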